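This account rests on a few compounds, and the source may have more. Where it says the series, first, only, none or still open, it means among the compounds named here.

Three compounds have been measured in a functional assay on NCI/ADR-RES cells (Homo sapiens) for inhibition, read by sulforhodamine B assay, with a stated time of 48 h; a higher number here means a weaker inhibitor of growth, a lower number a stronger inhibitor of growth:

compound 1, `N=C(N)c1ccc(-c2ccc(-c3ccc(Cl)cc3)s2)cc1F`, gives 361 nM;
compound 2, `COc1cc(OC)cc(-c2ccc(-c3ccc(C(=N)N)c(F)c3)s2)c1`, gives 1590 nM;
compound 3, `N=C(N)c1ccc(-c2ccc(-c3ccccc3)s2)cc1F`, gives 14100 nM.

Compound 2 stands second highest of these three numbers. Compound 1 sits below it and compound 3 above it, and both of those gaps lie beyond the usual scatter of the assay.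

Compound 4, `COc1cc(OC)cc(-c2ccc(-c3ccc(C(=N)N)cc3)s2)c1`, differs from compound 2 in a single place: hydrogen in place of fluoro on an aromatic carbon. Going by the values given here, the only measured step in the set, a 39-fold higher number from compound 1 to compound 3 (1.59 log units; beyond the scatter), is large, but it concerns a different change, the loss of chloro rather than of fluoro, so it does not speak directly to the present case. Among the compounds with values here, no measured pair tests the removal of fluoro from this position, and the three values give no guide to its direction. A step of small size is therefore expected in this assay, or none beyond the scatter, as a 1.4-fold higher number from compound 2 to compound 4 (0.14 log units; within the scatter). Compound 4 is estimated at 2200 nM, with a range from 700 nM to 7000 nM.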

Compound 4, concentration for 50% growth inhibition: 1970 nM
Beside the measured number, compound 4's estimate is 1.1-fold (0.05 log units) above it, within the range that was stated.
By their numbers in this assay, from the lowest: compound 1; then compounds 2 and 4 (each within the scatter of the next); then compound 3.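

In this assay, going by these compounds alone, hydrogen in place of fluoro gives a 1.2-fold higher number from compound 2 to compound 4 (0.09 log units; within the scatter), the first measured pair to test this aromatic carbon, ortho to a group of 3 heavy atoms and meta to a large group. With the rest of compound 2 unchanged, the fluoro can therefore be replaced by hydrogen without a change beyond the scatter, unlike the chloro exchange in a 39-fold higher number from compound 1 to compound 3 (1.59 log units; beyond the scatter), which lies at a different place. No measurement at hand offers an explanation for this result.

The compounds shown leave open whether the same exchange would also stay within the scatter in the setting of compound 1 or compound 3. They also leave open how an amine or a carboxylic acid on this aromatic carbon would compare with fluoro and hydrogen.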